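Adding methoxy: from compound 1 to compound 3

The source may hold more compounds than are shown below. What is called first, only, known or untested is meant among the compounds shown, and "the series" means these compounds.

In an ADME assay on J774 cells (Mus musculus) for cytotoxicity (on this read-out higher numbers stand for an effect only at larger amounts of compound and lower numbers for an effect already at smaller amounts), compound 1 (`COC(=O)c1c[nH]c2ccccc2c1=O`) stands at > 20000 nM, which is a limit of the assay and not a number. Compound 3 (`COC(=O)c1c[nH]c2ccc(OC)cc2c1=O`) differs from it by methoxy in place of hydrogen on an aromatic carbon. Among the measured compounds shown here, only one measured change bears on this: compound 2 (`COC(=O)c1c[nH]c2cc(Oc3ccccc3)ccc2c1=O`) has phenoxy in place of hydrogen on an aromatic carbon and gives 9120 nM. That is an at least 2.1-fold lower number from compound 1 to compound 2 (0.34 log units; beyond the scatter). For the measured compounds named here, with only this modest precedent, a small move toward lower numbers is expected at most, quite possibly none beyond the scatter. The expected change is a number no higher from compound 1 to compound 3 (the limit leaves the size open). For compound 3 the estimate is 20000 nM, with an expected range of 10000 nM to 40000 nM.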

Compound 3, half-maximal effective concentration: 6180 nM
Estimate against measurement, compound 3: 3.2-fold (0.51 log units) above; the measured number lies below the stated range.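

In this assay, methoxy in place of hydrogen on an aromatic carbon gives an at least 3.2-fold lower number from compound 1 to compound 3 (0.51 log units; beyond the scatter), so a group with no ring is enough to move the number down on this core. This holds at a carbon meta to a fused ring and para to a fused ring, not the carbon that carries phenoxy in compound 2. The full size of the step stays unknown, as compound 1 stands at a limit and not a number: the limit of > 20000 nM in this assay, at which 1 of the 3 values shown sits.

As far as these compounds go, whether an amine, a carboxylic acid or a longer chain such as ethoxy on this carbon would move the number the same way remains open. So does whether the oxygen attached to the ring is needed at all.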